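Cytotoxicity notes: aryl sulfonamide for propanamide on the core

The compounds below may be only part of what the source reports. "The series", "measured", "known", "first", "only" and "open" are said of these compounds alone.

Compounds measured so far in an ADME assay on MT4 cells (Homo sapiens) for cytotoxicity, read by MTT assay, with a stated time of 4 days; on this read-out lower numbers stand for higher toxicity in this test and higher numbers for lower toxicity in this test:
compound 1 `Cc1ccc(-c2c(C)c(-c3ccc4c(c3)CCO4)c(C(OC(C)(C)C)C(=O)O)c(C)c2NS(C)(=O)=O)cc1C` — 38000 nM
compound 2 `Cc1ccc(-c2c(C)c(-c3ccccc3)c(C(OC(C)(C)C)C(=O)O)c(C)c2NS(C)(=O)=O)cc1C` — > 50000 nM
compound 3 `CCC(=O)Nc1c(C)c(C(OC(C)(C)C)C(=O)O)c(-c2ccc(C)c(C)c2)c(C)c1-c1ccc(C)c(C)c1` — 15000 nM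

The value of compound 2 is a limit of this assay, not a number. Among the two numbers shown, compound 3 has the lowest; the one measured step, an at least 1.3-fold higher number from compound 1 to compound 2 (0.11 log units; that floor lies within the scatter), is known only as a floor, and compound 3 differs from compound 1 in more than one place, so their two values are compared only as they stand.

Compound 4 `Cc1ccc(-c2c(C)c(-c3ccc(C)c(C)c3)c(C(OC(C)(C)C)C(=O)O)c(C)c2NS(=O)(=O)c2ccccc2)cc1C` is not yet measured. It differs from compound 3 by phenylsulfonyl in place of propanoyl on a nitrogen on an aromatic ring. Among the compounds with values here, the only measured step, from compound 1 to compound 2, changes a group on an aromatic carbon and not the substituent on the ring nitrogen, so no measured step bears directly on this change; that step is also small, with its floor inside the scatter, and one value sits at the limit of > 50000 nM in this assay, at which 1 of the 3 values shown sits.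

With nothing shown to pull the number either way, the step from compound 3 to compound 4 is expected to stay near or within the scatter, estimated as a 1.3-fold lower number from compound 3 to compound 4 (0.10 log units; within the scatter). Compound 4 is therefore expected to give about 12000 nM, in the range 4000 nM to 40000 nM.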

Compound 4, half-maximal cytotoxic concentration: 11000 nM
Compound 4: middle estimate off by 1.1-fold (0.04 log units), on the high side; the range from low to high includes it.
By their numbers in this assay, from the lowest: compounds 4 and 3 (each within the scatter of the next); then compound 1. At a limit, above all of these: compound 2.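

In this assay, the ring nitrogen now has a measured step of its own: a 1.4-fold lower number from compound 3 to compound 4 (0.13 log units; within the scatter). The earlier step changed only a group on an aromatic carbon and was known only as a floor, whereas this one gives two numbers for a change at the nitrogen. Phenylsulfonyl brings a six-membered aromatic ring and more heavy atoms than propanoyl, yet this exchange on the shared core does not move the read-out beyond the scatter, and nothing shown accounts for the size of the step.

Going by these compounds, a single pair cannot show whether this holds for substituents on this nitrogen in general, so it remains open whether a longer chain, or a group carrying an amine or a carboxylic acid, would stay within the scatter in this assay. On these data alone, it is also open whether the same exchange would read alike with a pyridine ring in place of the phenyl of the phenylsulfonyl group, or with a different aromatic group on the core.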